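This account rests on a few compounds, and the source may have more. Where it says the series, first, only, none or still open, it means among the compounds named here.

Measured compounds:
compound 1, `CCN(CC)CN1C(=O)/C(=N\c2nc3ccc(C)cc3s2)c2ccccc21`, 63500 nM
compound 2, `Cc1ccc2nc(/N=C3\C(=O)N(CN(c4ccccc4)c4ccccc4)c4cccc(Cl)c43)sc2c1`, 85000 nM
compound 3, `CCN(CC)CN1C(=O)/C(=N\c2nc3ccc(C)cc3s2)c2c(Cl)cccc21`, 27300 nM

Of the compounds shown here, three have been tested in a functional assay on MDA-MB-468 cells (Homo sapiens) for cytotoxicity, read by sulforhodamine B assay, with a stated time of 48 h; a lower number here means a stronger inhibitor of growth, a higher number a weaker inhibitor of growth. Compound 3 gives 27300 nM, while compound 1 gives 63500 nM. The difference between them is hydrogen in place of chloro on an aromatic carbon, and the step was a 2.3-fold higher number from compound 3 to compound 1 (0.37 log units; beyond the scatter). Compound 2 gives 85000 nM; the difference between its core and that of compound 3 is not broken down here, and the values of compound 2 and compound 1 lie within the scatter of each other.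

Compound 4, `Cc1ccc2nc(/N=C3\C(=O)N(CN(c4ccccc4)c4ccccc4)c4ccccc43)sc2c1`, has not yet been measured in this assay. It differs from compound 2 by hydrogen in place of chloro on an aromatic carbon, the same change as that from compound 3 to compound 1. Because that earlier step was a 2.3-fold higher number from compound 3 to compound 1 (0.37 log units; beyond the scatter), compound 4 is expected to give a higher number than compound 2, with an estimated step of a 1.9-fold higher number from compound 2 to compound 4 (0.27 log units; within the scatter). On this basis compound 4 is estimated at 160000 nM, with a likely range from 60000 nM to 400000 nM, resting on a single precedent only.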

Compound 4, concentration for 50% growth inhibition: 17700 nM
For compound 4 the middle estimate is 9.0-fold (0.96 log units) above the measured one, outside the stated range (below it).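

In this assay, putting hydrogen in place of chloro on the aromatic carbon gives a 4.8-fold lower number from compound 2 to compound 4 (0.68 log units; beyond the scatter), so on the core of compound 2 the chloro compound is the weaker inhibitor of growth. On the core of compound 3 the chloro compound is the stronger one, and the change therefore does not carry from one core to the other, in either direction or size: the same change on two cores in this assay, a 2.3-fold higher number (0.37 log units; beyond the scatter) from compound 3 to compound 1 and a 4.8-fold lower number (0.68 log units; beyond the scatter) from compound 2 to compound 4, 11-fold (1.05 log units) apart, beyond the scatter of two such steps. The two pairs show that the outcome of this change depends on the core in this series, but they do not show which feature of the cores sets the direction, and two cores give no rule for predicting a third.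

The compounds shown leave open how a fluoro, bromo or methoxy group on the same aromatic carbon would read on either core. They also leave open whether a core carrying a morpholine in its side chain would follow the pair of compound 3 and compound 1 or the pair of compound 2 and compound 4.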